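This account rests on a few compounds, and the source may have more. Where it says the series, first, only, none or still open, it means among the compounds named here.

Working notes on the series. Going by the values given here, compound 3 `CC(C)N1CCc2nc(C#Cc3cccc(Cl)c3)ccc2C1=O` stands lowest of the three numbers so far in an assay on HEK293 cells for displacement of a labelled ligand from metabotropic glutamate receptor 5 (Homo sapiens), with a stated time of 2 h; a lower number here means a stronger inhibitor, a higher number a weaker inhibitor: compound 3 gives 100 nM, and both steps away from it lie beyond the scatter, so it is the strongest inhibitor measured here. Compound 2 `CC(C)N1CCc2nc(C#Cc3ccccc3Cl)ccc2C1=O` gives 5680 nM, and compound 1 `CN1CCc2nc(C#Cc3ccccn3)ccc2C1=O` gives 6240 nM.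

Compound 4 `CC(C)N1CCc2nc(C#Cc3ccccn3)ccc2C1=O` differs from compound 3 by pyridin-2-yl in place of 3-chlorophenyl on a triple-bonded carbon. Among the compounds with values here, only one measured step touches this part of the molecule: a 57-fold lower number from compound 2 to compound 3 (1.75 log units; beyond the scatter), which shows that the aryl group on the triple-bonded carbon governs a large swing in this assay. Within the data shown here, no measured pair isolates the exchange of 3-chlorophenyl for pyridin-2-yl at a fixed core. Compound 1, which already carries pyridin-2-yl on the triple-bonded carbon but differs from compound 4 elsewhere in the core, sits close to compound 2 in this assay, and both are far from compound 3.

On that basis compound 4 is expected to lose most of the gain seen in compound 3, with an estimated step of a 30-fold higher number from compound 3 to compound 4 (1.48 log units; beyond the scatter). The estimate for compound 4 in this assay is 3000 nM, with a range from 700 nM to 12000 nM.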

Compound 4, inhibition constant: 2740 nM
Compound 4: middle estimate off by 1.1-fold (0.04 log units), on the high side; measured number inside the range.
By their numbers in this assay, from the lowest: compound 3; then compound 4; then compounds 2 and 1 (each within the scatter of the next).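

In this assay the exchange at a fixed core gives a 27-fold higher number from compound 3 to compound 4 (1.44 log units; beyond the scatter) and so shows directly that, on the triple-bonded carbon, 3-chlorophenyl gives a far stronger inhibitor than pyridin-2-yl. Set against the other chlorophenyl, the same group gives a 2.1-fold lower number from compound 2 to compound 4 (0.32 log units; beyond the scatter) as a modest step beyond the scatter, so the large swing at this position belongs to 3-chlorophenyl in particular and not to chlorophenyl groups as a whole. Going by these compounds alone, with pyridin-2-yl held fixed, a 2.3-fold lower number from compound 1 to compound 4 (0.36 log units; beyond the scatter) gives a first reading of isopropyl in place of methyl on the amide-type nitrogen in a ring, and that step is also modest. Nothing available here accounts for these differences.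

The compounds shown leave open whether another group in place of 3-chlorophenyl on the triple-bonded carbon, such as 3-methoxyphenyl or 3-fluorophenyl, would match compound 3. They also leave open whether the isopropyl-for-methyl step keeps its size when 3-chlorophenyl is on the triple-bonded carbon, and how a cyclopropyl group or a longer chain on that nitrogen would read.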